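The source may report more compounds than this note shows. Statements on the series, on what has been measured and on what is new or still open speak of the compounds shown alone.

Compound 1 `O=C(Nc1ccc(N(CC2CC2)CC2CC2)cc1Cl)c1cc(Cl)ccc1O` is the starting point. Among the compounds with values here, in an ADME assay on A549 cells (Homo sapiens) for cytotoxicity, read by resazurin assay, with a stated time of 48 h (a higher number here means that more compound is tolerated, a lower number that less compound is tolerated), compound 1 gives 12800 nM, the lowest of the three numbers measured so far. Compound 2 `O=C(Nc1ccc(NCc2cc(Cl)cc(C(F)(F)F)c2)cc1Cl)c1cc(Cl)ccc1O` gives 30900 nM in this assay, and compound 3 `O=C(Nc1ccc(NCc2cc(F)cc(C(F)(F)F)c2)cc1Cl)c1cc(Cl)ccc1O` gives 30900 nM. Within the data shown here, the one measured step, no change at the digits printed from compound 2 to compound 3 (within the scatter), swaps fluoro for chloro on an aromatic carbon and does not touch the amine side.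

Compound 4 `O=C(Nc1ccc(NCc2cccc(Br)n2)cc1Cl)c1cc(Cl)ccc1O` differs from compound 1 in one place: ((6-bromopyridin-2-yl)methyl)amino in place of bis(cyclopropylmethyl)amino on an aromatic carbon. Among the measured compounds shown here, no measured step covers this change. Compounds 2 and 3 also carry a single arylmethylamino group at that place; compound 2 gives 30900 nM and compound 3 gives 30900 nM, against compound 1 at 12800 nM. A move of similar size in the same direction is expected, a 2.0-fold higher number from compound 1 to compound 4 (0.29 log units; within the scatter). Compound 4 is therefore estimated at 25000 nM, within 10000 nM to 60000 nM.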

Compound 4, half-maximal cytotoxic concentration: 92300 nM
The estimate for compound 4 lay 3.7-fold (0.57 log units) below the measured number; measured number above the stated range.
By their numbers in this assay, from the lowest: compound 1; then compounds 2 and 3 (each within the scatter of the next); then compound 4.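

In this assay, the group on this aromatic carbon clearly affects how much compound the cells tolerate: ((6-bromopyridin-2-yl)methyl)amino in place of bis(cyclopropylmethyl)amino gives a 7.2-fold higher number from compound 1 to compound 4 (0.86 log units; beyond the scatter). Within the data shown here, this is the first measured step at this place, and it replaces two three-membered carbon rings with one six-membered aromatic ring, adding a hydrogen-bond donor and bromine in a single change. Nothing measured here explains the rise. Still open, as far as these compounds go, is which of these differences carries the step, and what a plain (pyridin-2-yl)methylamino group, without bromine, would give at this place.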